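A few compounds are considered here, and "the series" means these few. Any claim that something is new, unique, unknown or untested is made for them only; others in the source may bear on it.

Compound 1 `Cn1c(C2CC2)nc2ccc(-n3ccc(OCc4ccc(F)cc4)cc3=O)cc21`: 28 nM
Compound 2 `Cn1c(C2CC2)nc2ccc(-n3ccc(OCc4ccccc4Cl)cc3=O)cc21`: 140 nM

In an assay on CHO cells for displacement of a labelled ligand from melanin-concentrating hormone receptor 1 (Rattus norvegicus), read by scintillation counting, with a stated time of 1 h (on this read-out lower numbers stand for stronger inhibition and higher numbers for weaker inhibition), compound 2 stands at the highest of the two numbers; its nearest neighbour is compound 1, and the step of a 5.0-fold higher number from compound 1 to compound 2 (0.70 log units; beyond the scatter) lies beyond the scatter. Compound 3 `Cn1c(C2CC2)nc2ccc(-n3ccc(OCc4cc(C(F)(F)F)cs4)cc3=O)cc21` differs from compound 2 by 4-(trifluoromethyl)thiophen-2-yl in place of 2-chlorophenyl on a saturated chain carbon bound to an oxygen on an aromatic ring. For the measured compounds named here, the one measured step at this place, a 5.0-fold higher number from compound 1 to compound 2 (0.70 log units; beyond the scatter), shows that exchanging the ring there can move the number beyond the scatter, but no measured step involves a thiophene, so the direction is open. Compound 3 is therefore expected to give 100 nM, between 25 nM and 400 nM, a step of a 1.4-fold lower number from compound 2 to compound 3 (0.15 log units; within the scatter) expected to stay within the scatter.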

Compound 3, half-maximal inhibitory concentration: 17 nM
Beside the measured number, compound 3's estimate is 5.9-fold (0.77 log units) above it, outside the stated range (below it).
By their numbers in this assay, from the lowest: compounds 3 and 1 (each within the scatter of the next); then compound 2.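

The ring at this place need not be a six-membered aromatic ring of carbon only: in this assay, 4-(trifluoromethyl)thiophen-2-yl in place of 2-chlorophenyl gives an 8.2-fold lower number from compound 2 to compound 3 (0.92 log units; beyond the scatter). Set against 4-fluorophenyl, the same group gives a 1.6-fold lower number from compound 1 to compound 3 (0.22 log units; within the scatter), so the five-membered ring matches the level of the 4-fluorophenyl compound within the scatter. Nothing shown here gives a reason for these steps. The compounds shown do not separate the thiophene ring from its trifluoromethyl group. As far as these compounds go, how a thiophene without trifluoromethyl, an amine or a carboxylic acid would fare at this place remains open.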